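The source may report more compounds than this note shows. Statements on the series, on what has been measured and on what is new or still open speak of the compounds shown alone.

Compound 1 `CC(C)[C@@H]1CC[C@@H](C)C[C@@]12N(C)C(=O)[C@@H]1[C@H]3C(=O)NC(=O)[C@H]3ON12` gives 38%; compound 2 `CC(C)[C@@H]1CC[C@@H](C)C[C@@]12N(C)C(=O)[C@@H]1[C@H]3C(=O)N(C)C(=O)[C@H]3ON12` gives 57.2%; compound 3 `CC(C)[C@@H]1CC[C@@H](C)C[C@@]12N(C)C(=O)[C@@H]1[C@H]3C(=O)N(c4ccccc4)C(=O)[C@H]3ON12` gives 53.1%.

In a functional assay, read by spectrophotometry, with a stated time of 2 h, tested at 2.5 mg/mL (on this read-out lower numbers stand for a weaker effect and higher numbers for a stronger effect at the one concentration tested), compound 3 holds the second highest of the three numbers: it sits within the scatter of compound 2, as a number 4.1 percentage points lower from compound 2 to compound 3 (within the scatter) shows, and beyond the scatter of compound 1, as a number 15.1 percentage points higher from compound 1 to compound 3 (beyond the scatter) shows. Compound 4 `CC(C)[C@@H]1CC[C@@H](C)C[C@@]12N(C)C(=O)[C@@H]1[C@H]3C(=O)N(c4ccc(Cl)cc4)C(=O)[C@H]3ON12` differs from compound 3 by chloro in place of hydrogen on an aromatic carbon. Among the measured compounds shown here, no measured step touches the six-membered aromatic ring of carbon only; the steps seen, a number 19.2 percentage points higher from compound 1 to compound 2 (beyond the scatter) and a number 15.1 percentage points higher from compound 1 to compound 3 (beyond the scatter), exchange the group on the amide-type nitrogen itself, and methyl against phenyl there gave only a number 4.1 percentage points lower from compound 2 to compound 3 (within the scatter). With nothing that bears directly on a chloro, the expected step is none beyond the scatter, a number 0.1 percentage points lower from compound 3 to compound 4 (within the scatter). Compound 4 is estimated at 53%, between 40% and 66%.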

Compound 4, a percentage reported as activity, at one concentration (the size of the read-out at that concentration, not a potency): 61.3%
The estimate for compound 4 lay 8.3 percentage points below the measured number; the range from low to high includes it.
By their numbers in this assay, from the lowest: compound 1; then compounds 3, 2 and 4 (each within the scatter of the next).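

In this assay, among the compounds shown here, the first change on the aromatic ring itself, phenyl to 4-chlorophenyl, leaves the read-out within the scatter (a number 8.2 percentage points higher from compound 3 to compound 4 (within the scatter)). The chloro compound also stays within the scatter of the methyl compound (a number 4.1 percentage points higher from compound 2 to compound 4 (within the scatter)), while its gap from the compound with the amide hydrogen remains beyond it (a number 23.3 percentage points higher from compound 1 to compound 4 (beyond the scatter)). No measurement here offers an explanation for these results. The compounds shown leave open how an amine, a carboxylic acid or a methoxy group on this aromatic carbon would read, and whether a longer chain on the amide-type nitrogen would match the aryl groups.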